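The source may hold more compounds than are shown below. What is called first, only, known or untested is meant among the compounds shown, and "the series" means these compounds.

Measured so far in a functional assay on HCT-15 cells (Homo sapiens) for cytotoxicity, read by sulforhodamine B assay; a higher number here means a weaker inhibitor, a lower number a stronger inhibitor:
Compound 1, `COc1cc(-c2ccccc2)cc(OC)c1O`: > 10000 nM
Compound 2, `COc1cc(OC)cc(-c2ccccc2)c1`: > 10000 nM

Compound 1 returns only a limit in this assay, > 10000 nM. Compound 2 also returns only a limit in this assay, > 10000 nM. Among the compounds with values here, the single measured step, a step that the two limits leave unreadable from compound 1 to compound 2, is therefore not readable in size or direction, and the whole of the evidence so far is the limit of > 10000 nM in this assay, at which 2 of the 2 values shown sit.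

Compound 3, `COc1cc(OC)cc(-c2ccc(O)cc2)c1`, differs from compound 2 by hydroxy in place of hydrogen on an aromatic carbon. Within the data shown here, no measured step touches a change of this kind, and the one step available gives no readable size, so there is nothing to point to a shift beyond the scatter in either direction. Compound 3 is accordingly expected to sit near the limit as well, at an estimated 15000 nM (range 5000 nM to 50000 nM). The step that the limit leaves unreadable from compound 2 to compound 3 is expected to be small, with a high chance that compound 3 is again reported only as a limit.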

Compound 3, half-maximal inhibitory concentration: > 10000 nM
Compound 3: a limit, no number; the forecaster's own chance of this, stated with the estimate: 70%; the middle value is on the limit's open side.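

Compound 2 and compound 3 both return only limits in this assay, so the step between them cannot be read in either size or direction. The compounds shown leave open whether any change on the shared core gives a number rather than a limit, as all the evidence so far is this: the limit of > 10000 nM in this assay, at which 3 of the 3 values shown sit.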